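Dichloro variant of the aryl ring on the dihydropyridazinone series

A few compounds are considered here, and "the series" means these few. Any claim that something is new, unique, unknown or untested is made for them only; others in the source may bear on it.

Measured so far:
Compound 1, `CS(=O)(=O)c1ccc(N2N=C(c3ccccc3)CCC2=O)cc1`: in a functional assay on the whole organism (strain Wistar) for inhibition, with Rattus norvegicus as the target, read by paw edema, with stated times of 30 min and 5 h, at a dose of 0.05 mmol/kg by the oral route (on this read-out lower numbers stand for less inhibition and higher numbers for more inhibition at the one dose given (going by the name of the read-out)), compound 1 gives 47.3%.
Compound 2, `COc1ccc(C2=NN(c3ccc(S(C)(=O)=O)cc3)C(=O)CC2)cc1OC`: in this assay compound 2 gives 82.4%.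
Compound 3, `CS(=O)(=O)c1ccc(N2N=C(c3ccc(Br)cc3)CCC2=O)cc1`: in this assay compound 3 gives 31.5%.

Compound 1 stands second highest of the three numbers. Its nearest neighbour is compound 3, which lies below it beyond the scatter; compound 2, with the dimethoxy-bearing ring, lies well above it, also beyond the scatter. Going by the values given here, no single-point step links compound 1 and compound 2, so their two values are simply noted side by side.

The compound now in question is compound 4, `CS(=O)(=O)c1ccc(N2N=C(c3ccc(Cl)c(Cl)c3)CCC2=O)cc1`. Relative to compound 1 the change is 3,4-dichlorophenyl in place of phenyl on a carbon with a double bond to nitrogen.

Among the compounds with values here, the only measured step that bears on this is a number 15.8 percentage points lower from compound 1 to compound 3 (beyond the scatter), where a single halogen on the same ring took the read-out down by a modest amount. Compound 4 carries two chlorines on that ring, and nothing among the three measured compounds says that a second halogen would reverse the direction seen with one. The step of a number 19.3 percentage points lower from compound 1 to compound 4 (beyond the scatter) is therefore expected to be downward, comparable to or somewhat larger than the bromo step, though the wide scatter of the read-out leaves room for a flat result.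

Compound 4 is accordingly estimated at 28%, with a range of 10% to 46%.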

Compound 4, a percentage reported as inhibition, in the whole organism at one dose (the size of the read-out at that dose, not a potency): 34.2%
For compound 4 the middle estimate is 6.2 percentage points below the measured one; low and high end bracket the measured number.
By their numbers in this assay, from the lowest: compounds 3 and 4 (each within the scatter of the next); then compound 1; then compound 2.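

In this assay, 3,4-dichlorophenyl in place of phenyl on the carbon with a double bond to nitrogen gives a number 13.1 percentage points lower from compound 1 to compound 4 (beyond the scatter), which places a second halogen-bearing ring on the same side of the unsubstituted phenyl as the bromo change, a number 15.8 percentage points lower from compound 1 to compound 3 (beyond the scatter). The direct comparison of the two halogen-bearing rings gives a number 2.7 percentage points higher from compound 3 to compound 4 (within the scatter), so 4-bromophenyl and 3,4-dichlorophenyl cannot be told apart at this position on this read-out, and the presence of two chlorines rather than one bromine has no visible consequence here. No measurement at hand gives a reason for either step.

Among the compounds shown, the lower numbers go with halogen on this ring, but two examples do not make a rule, and the dimethoxy-bearing compound 2, at 82.4%, shows that substitution on this ring does not as such lower the number. Open questions are which of the two chlorines carries the step from the phenyl compound, and whether a fluoro, an amine or a carboxylic acid on this ring would fall with the halogen compounds or nearer compound 2.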